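Swapping the aryl sulfone substituent in a quinoline series

The compounds below may be only part of what the source reports. "The series", "measured", "known", "first", "only" and "open" are said of these compounds alone.

Compounds measured so far in an ADME assay on microsomes from liver (Homo sapiens) for metabolic stability, tested at 2.5 uM; on this read-out lower numbers stand for slow clearance and higher numbers for fast clearance:
Compound 1, `COc1ccc(-c2c(S(=O)(=O)c3cc(F)cc(F)c3)cnc3c(F)cccc23)cc1`, gives 2.59 mL/min.
Compound 2, `COc1cccc(S(=O)(=O)c2cnc3cc(F)ccc3c2-c2cccc(Cl)c2)c1`, gives 2.97 mL/min.
Compound 3, `COc1cccc(S(=O)(=O)c2cnc3cc(F)ccc3c2-c2cccc(F)c2)c1`, gives 3.36 mL/min.

Among these three numbers compound 3 gives the highest, yet its nearest neighbour compound 2 and its furthest neighbour compound 1 both sit within the scatter of it, so no ordering among them can be claimed. Going by the values given here, the one step between close analogues, a 1.1-fold higher number from compound 2 to compound 3 (0.05 log units; within the scatter), also stays within the scatter.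

Compound 4, `Cc1ccc(S(=O)(=O)c2cnc3cc(F)ccc3c2-c2cccc(F)c2)cc1F`, is not yet measured. It differs from compound 3 as follows: 3-fluoro-4-methylphenyl in place of 3-methoxyphenyl on a sulfonyl sulfur. Among the compounds with values here, no measured pair shows this exchange, and the single step that exists concerns a different part of the molecule and was itself small. With only within-scatter movement seen across the set, compound 4 is expected to land near compound 3, with a step of a 1.1-fold lower number from compound 3 to compound 4 (0.02 log units; within the scatter) in this assay. The estimate for compound 4 is 3.2 mL/min, with a range from 1.6 mL/min to 6.4 mL/min.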

Compound 4, intrinsic clearance in a liver preparation (reported as CLH), per the amount of preparation that the assay uses: 0.41 mL/min
Compound 4: the middle estimate sits 7.8-fold (0.89 log units) above what was measured; the whole stated range lies above it.
By their numbers in this assay, from the lowest: compound 4; then compounds 1, 2 and 3 (each within the scatter of the next).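

Going by these compounds alone, the exchange of 3-methoxyphenyl for 3-fluoro-4-methylphenyl on a sulfonyl sulfur gives, in this assay, an 8.2-fold lower number from compound 3 to compound 4 (0.91 log units; beyond the scatter), the first step in the set that lies beyond the scatter. The earlier step, a 1.1-fold higher number from compound 2 to compound 3 (0.05 log units; within the scatter), concerned a different part of the molecule and stayed within the scatter, so only now is this position seen to move the read-out, even though the two groups match in heavy atoms and each carries one six-membered aromatic ring. Nothing shown here bears on why the number fell.

The methoxy group leaves as the fluoro and methyl groups enter, so the compounds shown cannot say which of these changes carries the step. As far as these compounds go, how a carboxylic acid or a primary amine on that ring would read also remains open.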